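The compounds below may be only part of what the source reports. "The series", "measured", "known", "first", "only" and "open" are said of these compounds alone.

Measured so far:
compound 1, `O=[N+]([O-])c1cccc(/N=N/N2CCCC2)c1`, in an ADME assay on MT4 cells (Homo sapiens) for cytotoxicity, read by MTT assay, with a stated time of 96 h; a higher number here means that more compound is tolerated, a lower number that less compound is tolerated: 66000 nM
compound 2, `CN(C)CCCNc1ccc(/N=N/c2ccc([N+](=O)[O-])cc2)cc1`, in this assay: 19000 nM

Compound 1 stands highest of the two numbers in this assay, and its nearest neighbour is compound 2, whose value lies beyond the scatter below it. Compound 3, `FC(F)(F)c1cccc(/N=N/N2CCCC2)c1`, has not yet been measured in this assay. It differs from compound 1 in one place: trifluoromethyl in place of nitro on an aromatic carbon, sitting on an aromatic carbon of a six-membered aromatic ring of carbon only, meta to a group of 7 heavy atoms. Among the compounds with values here, no measured pair in this set shows what such a change does here, so the step from compound 1 to compound 3 can only be expected rather than read off. The expected step in this assay is a modest downward one, a 1.7-fold lower number from compound 1 to compound 3 (0.22 log units; within the scatter), not far beyond the scatter. For compound 3 the estimate in this assay is 40000 nM, with a range from 15000 nM to 120000 nM.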

Compound 3, half-maximal cytotoxic concentration: > 100000 nM
Compound 3 gave a limit, no number; the forecaster's own chance of this, stated with the estimate: 20%; middle value at least 2.5-fold (0.39 log units) from the limit.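

Trifluoromethyl in place of nitro on an aromatic carbon gives, in this assay, an at least 1.5-fold higher number from compound 1 to compound 3 (0.18 log units; that floor lies within the scatter). Compound 3 carries a limit of the assay and not a number: the limit of > 100000 nM in this assay, at which 1 of the 3 values shown sits. As far as these compounds go, this first pair differing in one place shows that, at this position on the core of compound 1, nitro can be replaced without any loss in the amount of compound tolerated, although the floor of the step does not establish a true rise and its full size remains unknown.

From the compounds shown here alone, whether a nitrile or a carboxylic acid at the same position would keep the number this high remains open, as does the outcome with a bare hydrogen there. Also open, going by these compounds, is what would happen if the group of 7 heavy atoms gave way to a longer chain.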